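This account rests on a few compounds, and the source may have more. Where it says the series, first, only, none or still open, it means among the compounds named here.

Of the compounds shown here, three built on one shared core have been measured in an assay on CHO cells for agonist activity at 5-hydroxytryptamine receptor 1D (Homo sapiens), read by GTPgammaS binding; a higher number here means that more compound is needed for the effect, a lower number that less compound is needed. Compound 1 `O=S(=O)(NCC1CCN(CCCc2c[nH]c3ccc(-n4cnnc4)cc23)CC1)c1ccccc1` gives 12 nM. Compound 2 `COC[C@H](NC1CCN(CCCc2c[nH]c3ccc(-n4cnnc4)cc23)CC1)c1ccccc1` gives 0.9 nM. Compound 3 `c1cc(CNC2CCN(CCCc3c[nH]c4ccc(-n5cnnc5)cc34)CC2)co1` gives 7.1 nM. Among these three numbers compound 3 holds the second highest place: the gap to compound 1 is small, as a 1.7-fold lower number from compound 1 to compound 3 (0.23 log units; within the scatter) shows, while the gap to compound 2 is the widest, as a 7.9-fold higher number from compound 2 to compound 3 (0.90 log units; beyond the scatter) shows.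

Compound 4 `OCCC(NC1CCN(CCCc2c[nH]c3ccc(-n4cnnc4)cc23)CC1)c1ccccc1` has not yet been measured. It differs from compound 3 in one place: 3-hydroxy-1-phenylpropyl in place of (furan-3-yl)methyl on an amine nitrogen. The group that enters resembles the 2-methoxy-1-phenylethyl group of compound 2, in that both place a phenyl ring and a single oxygen within the group on the amine nitrogen, whereas compound 3 carries a small furan there. The step that bears most directly on this change is a 7.9-fold higher number from compound 2 to compound 3 (0.90 log units; beyond the scatter), which ran in the opposite direction, and a 13-fold lower number from compound 1 to compound 2 (1.12 log units; beyond the scatter) points the same way. A move back toward the number of compound 2 is therefore expected, of modest size in this assay, with the expected step being a 3.9-fold lower number from compound 3 to compound 4 (0.60 log units; beyond the scatter). Compound 4 is estimated to give about 1.8 nM, with a likely range from 0.6 nM to 5.5 nM.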

Compound 4, half-maximal effective concentration: 5.1 nM
For compound 4 the middle estimate is 2.8-fold (0.45 log units) below the measured one; the measured number falls inside the stated range.
By their numbers in this assay, from the lowest: compound 2; then compounds 4, 3 and 1 (each within the scatter of the next, the first and the last beyond it).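

In this assay, a phenyl ring and an oxygen on the amine nitrogen are not enough on their own to reach the low number of compound 2: replacing (furan-3-yl)methyl with 3-hydroxy-1-phenylpropyl gives a 1.4-fold lower number from compound 3 to compound 4 (0.14 log units; within the scatter) and so leaves the two compounds indistinguishable. The clear difference lies between the two phenyl-bearing groups, with a 5.7-fold higher number from compound 2 to compound 4 (0.75 log units; beyond the scatter) showing that the result depends on the particular group and not simply on the presence of a phenyl ring. Compound 4 still keeps a modest edge over the ((phenylsulfonyl)amino)methyl compound, as a 2.4-fold lower number from compound 1 to compound 4 (0.37 log units; beyond the scatter) shows, but no measured evidence is available to explain any of these steps.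

The groups on compound 2 and compound 4 differ in more than one feature, including a methoxy against a hydroxy and a different chain, so these compounds cannot show which feature accounts for their gap. On these data alone, a 2-hydroxy-1-phenylethyl or a 3-methoxy-1-phenylpropyl group would change those features one at a time, and how a terminal amine or carboxylic acid on the chain would fare also remains open.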